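Swapping a Benzyl Urea for an Aryl Urea

A few compounds are considered here, and "the series" means these few. Any claim that something is new, unique, unknown or untested is made for them only; others in the source may bear on it.

Of the compounds shown here, three that share one core have been measured in an assay on IM-9 cells for binding affinity to Substance-P receptor (Homo sapiens); on this read-out lower numbers stand for stronger inhibition and higher numbers for weaker inhibition. Compound 1 `Cc1cc2c(-c3ccccc3)c(NC(=O)N(C)Cc3ccccc3)n(C)c(=O)c2cc1C` gives 16 nM, compound 2 `CCN(Cc1ccccc1)C(=O)Nc1c(-c2ccccc2)c2cc(C)c(C)cc2c(=O)n1C` gives 66 nM, and compound 3 `Cc1cc(C)cc(CN(C)C(=O)Nc2c(-c3ccccc3)c3cc(C)c(C)cc3c(=O)n2C)c1` gives 28 nM. Compound 3 thus stands second highest of the three; its nearest neighbour is compound 1, and the step of a 1.8-fold higher number from compound 1 to compound 3 (0.24 log units; within the scatter) lies within the scatter, while the step of a 2.4-fold lower number from compound 2 to compound 3 (0.37 log units; beyond the scatter) lies beyond it.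

Compound 4 `Cc1cccc(NC(=O)Nc2c(-c3ccccc3)c3cc(C)c(C)cc3c(=O)n2C)c1` differs from compound 3 in one place: (3-methylphenyl)amino in place of (3,5-dimethylbenzyl)(methyl)amino on a carbonyl carbon. This removes the methyl on the urea nitrogen and brings the aromatic ring one carbon closer to that nitrogen, adding a hydrogen-bond donor. Among the compounds with values here, no measured step makes exactly this change. The closest guide is a 4.1-fold higher number from compound 1 to compound 2 (0.62 log units; beyond the scatter), which shows that even a small change at the urea nitrogen can move this assay beyond the scatter, whereas a 1.8-fold higher number from compound 1 to compound 3 (0.24 log units; within the scatter) shows that methyls on the ring barely matter. Because the change in compound 4 is larger than the change behind a 4.1-fold higher number from compound 1 to compound 2 (0.62 log units; beyond the scatter), a shift beyond the scatter in this assay is expected, most likely toward a higher number.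

Compound 4 is therefore estimated at 80 nM, within a range of 15 nM to 450 nM, a step of a 2.9-fold higher number from compound 3 to compound 4 (0.46 log units; beyond the scatter).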

Compound 4, half-maximal inhibitory concentration: 840 nM
The estimate for compound 4 lay 11-fold (1.02 log units) below the measured number; the measured number lies above the stated range.
By their numbers in this assay, from the lowest: compounds 1 and 3 (each within the scatter of the next); then compound 2; then compound 4.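

In this assay, within the data shown here, the group on this carbonyl carbon proves far more sensitive than the earlier compounds suggested: their steps were modest or within the scatter, whereas (3-methylphenyl)amino in place of (3,5-dimethylbenzyl)(methyl)amino gives a 30-fold higher number from compound 3 to compound 4 (1.48 log units; beyond the scatter) and so moves the number much further than any earlier change. The other two comparisons agree, with a 13-fold higher number from compound 2 to compound 4 (1.10 log units; beyond the scatter) against benzyl(ethyl)amino and a 53-fold higher number from compound 1 to compound 4 (1.72 log units; beyond the scatter) against benzyl(methyl)amino, which leaves compound 4 the weakest of the four and well apart from the rest. No supporting measurement is available that bears on the reason for this jump.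

On these data alone, what stays open is whether the jump follows the lost methyl on the nitrogen, the added hydrogen-bond donor or the missing chain carbon, all of which arrive together in compound 4. A benzylamino group, which keeps the chain carbon but carries hydrogen on the nitrogen, and a methyl(phenyl)amino group, which keeps the methyl but lacks the chain carbon, would begin to pull these changes apart.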